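A few compounds are considered here, and "the series" means these few. Any claim that something is new, unique, unknown or untested is made for them only; others in the source may bear on it.

In a functional assay on A375M cells (Homo sapiens) for cytotoxicity, read by MTT assay, with a stated time of 4 days (on this read-out lower numbers stand for stronger inhibition and higher numbers for weaker inhibition), compound 1 `C=C1C(=O)OC(c2ccccc2)C1CCCC` gives 7800 nM and compound 2 `C=C1C(=O)OC(CCCC)C1CCc1ccccc1` gives 5500 nM, two numbers within the usual scatter of each other. Compound 3 `C=C1C(=O)OC(c2ccccc2)C1CCc1ccccc1` differs from compound 2 in one place: phenyl in place of butyl on a saturated ring carbon. Compound 1 also carries phenyl on that ring carbon and gives 7800 nM, so no step beyond the scatter is expected in this assay. The estimated step, a 1.1-fold lower number from compound 2 to compound 3 (0.04 log units; within the scatter), is therefore small. For compound 3 the expected value is 5000 nM, with an estimated range from 2000 nM to 12000 nM.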

Compound 3, half-maximal inhibitory concentration: 2800 nM
For compound 3 the middle estimate is 1.8-fold (0.25 log units) above the measured one, and the stated range covers the measured number.
By their numbers in this assay, from the lowest: compounds 3, 2 and 1 (each within the scatter of the next, the first and the last beyond it).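

In this assay, phenyl in place of butyl on a saturated ring carbon, next to the ring oxygen, gives a 2.0-fold lower number from compound 2 to compound 3 (0.29 log units; within the scatter), so this change shows no clear effect on its own. Phenyl in place of ethyl on a saturated chain carbon gives a 2.8-fold lower number from compound 1 to compound 3 (0.44 log units; beyond the scatter), a modest step and the only one here that lies beyond the scatter. No measurement given here explains either step. On these data alone, whether an amine, a carboxylic acid or a longer chain on that ring carbon would keep this level remains open.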